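Ring-opened amide at the pyrrole of compound 2

The compounds below may be only part of what the source reports. "The series", "measured", "known", "first", "only" and "open" are said of these compounds alone.

Among the compounds with values here, compound 2 `COc1cc(-n2cccc2C(=O)N2CCCC2)ccc1Nc1ncc(Cl)c(Nc2ccccc2NS(C)(=O)=O)n1` gives 4580 nM in a functional assay on A549 cells (Homo sapiens) for antiproliferative activity, read by MTT assay, with a stated time of 72 h (on this read-out higher numbers stand for weaker inhibition and lower numbers for stronger inhibition), the highest of the three numbers measured so far. Its nearest neighbour is compound 1 `COC(=O)c1cccn1-c1ccc(Nc2ncc(Cl)c(Nc3ccccc3NS(C)(=O)=O)n2)c(OC)c1`, which gives 2510 nM in this assay, a step of a 1.8-fold higher number from compound 1 to compound 2 (0.26 log units; within the scatter). Compound 3 `COc1cc(-n2cccc2C(=O)N2CCC(C)CC2)ccc1Nc1ncc(Cl)c(Nc2ccccc2NS(C)(=O)=O)n1` gives 2200 nM in this assay, and the step of a 2.1-fold lower number from compound 2 to compound 3 (0.32 log units; beyond the scatter) is the only one among the three that reaches beyond the scatter. Compound 4 `CCN(CC)C(=O)c1cccn1-c1ccc(Nc2ncc(Cl)c(Nc3ccccc3NS(C)(=O)=O)n2)c(OC)c1` differs from compound 2 by diethylamino in place of pyrrolidin-1-yl on a carbonyl carbon. The two amide steps that touch compound 2, namely a 1.8-fold higher number from compound 1 to compound 2 (0.26 log units; within the scatter) and a 2.1-fold lower number from compound 2 to compound 3 (0.32 log units; beyond the scatter), both stay small, so replacing one amide substituent of five heavy atoms by another of the same count is expected to move the number little, with at most a modest fall, in this assay. Compound 4 is therefore estimated at 3500 nM in this assay, within a range from 1500 nM to 8000 nM, corresponding to an expected step of a 1.3-fold lower number from compound 2 to compound 4 (0.12 log units; within the scatter).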

Compound 4, half-maximal inhibitory concentration: 970 nM
Compound 4: middle estimate off by 3.6-fold (0.56 log units), on the high side; measured number below the stated range.
By their numbers in this assay, from the lowest: compound 4; then compounds 3, 1 and 2 (each within the scatter of the next, the first and the last beyond it).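

In this assay, within the data shown here, the group on the carbonyl carbon matters more than the earlier compounds showed: diethylamino in place of pyrrolidin-1-yl, with the same count of heavy atoms, gives a 4.7-fold lower number from compound 2 to compound 4 (0.67 log units; beyond the scatter) and is the largest step in this small set. The other two comparisons, a 2.3-fold lower number from compound 3 to compound 4 (0.36 log units; beyond the scatter) and a 2.6-fold lower number from compound 1 to compound 4 (0.41 log units; beyond the scatter), are also beyond the scatter, so compound 4 is the most potent of the four and the heavy-atom count alone does not set the number at this place. Nothing measured here accounts for this separation.

The compounds shown leave open whether the lower number belongs to open-chain amides in general or to diethylamino alone. Dimethylamino, dipropylamino or a free carboxylic acid on the same carbonyl carbon would each bear on that question.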